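The compounds below may be only part of what the source reports. "The series", "measured", "known", "first", "only" and "open" are said of these compounds alone.

In a functional assay on HepG2 cells (Homo sapiens) for antiproliferative activity, read by MTT assay, with a stated time of 24 h (on this read-out lower numbers stand for stronger inhibition and higher numbers for weaker inhibition), compound 1 `O=c1[nH]cc(S(=O)(=O)Nc2ccc(-c3cn(-c4ccccc4F)nn3)cc2)c(=O)[nH]1` gives only a limit, > 20000 nM. Compound 2 `O=c1[nH]cc(S(=O)(=O)Nc2ccc(-c3cn(-c4cccc(F)c4)nn3)cc2)c(=O)[nH]1` likewise yields no number in this assay but only a limit, > 20000 nM. The step in this assay, a step that the two limits leave unreadable from compound 1 to compound 2, cannot be read because of the limit of > 20000 nM in this assay, at which 2 of the 2 values shown sit. Among the compounds with values here, compound 2 thus stands at the limit of this assay, and so does the one other value shown, so nothing measured here gives a number to anchor on.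

Compound 3 `O=c1[nH]cc(S(=O)(=O)Nc2ccc(-c3cn(-c4cccc(Cl)c4)nn3)cc2)c(=O)[nH]1` differs from compound 2 by chloro in place of fluoro on an aromatic carbon, with the shared core and the rest of the molecule untouched. Within the data shown here, the only measured step that bears on this change is the one from compound 1 to compound 2, and it has no readable size, so the data give neither a direction nor a size for the exchange of fluoro for chloro. With both measured compounds sitting at the limit, compound 3 is expected to remain at or beyond it as well. The estimate for compound 3 in this assay is 30000 nM, with a range from 8000 nM to 100000 nM, which means an expected step that the limit leaves unreadable from compound 2 to compound 3.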

Compound 3, half-maximal inhibitory concentration: 2020 nM
The estimate for compound 3 lay 15-fold (1.17 log units) above the measured number, outside the stated range (below it).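

In this assay, chloro in place of fluoro on an aromatic carbon, meta to a large group, yields the only number among the three compounds shown, with an at least 9.9-fold lower number from compound 2 to compound 3 (0.99 log units; beyond the scatter). A second comparison, at the aromatic nitrogen, gives an at least 9.9-fold lower number from compound 1 to compound 3 (0.99 log units; beyond the scatter), so 3-chlorophenyl stands clear of both fluorinated phenyl groups, whereas the step between the two fluorinated compounds themselves cannot be read. The identity of the halogen at this position therefore matters in a way the earlier pair could not show, yet both new steps give only a minimum size, because each starts from a limit and not from a number: the limit of > 20000 nM in this assay, at which 2 of the 3 values shown sit.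

The compounds shown do not reveal how far the exchange would carry with bromo, methyl or methoxy on the same aromatic carbon, or whether the gain is particular to chloro. They also leave open whether chloro would have a comparable effect at another carbon of this ring, so the result speaks for the 3-chlorophenyl group alone.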